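Bis-sulfonamide piperidine series: amide substituent change

A few compounds are considered here, and "the series" means these few. Any claim that something is new, unique, unknown or untested is made for them only; others in the source may bear on it.

Of the compounds shown here, three of the shared core have numbers so far. In a functional assay on MIA PaCa-2 cells (Homo sapiens) for inhibition, read by MTT assay, with a stated time of 3 days (on this read-out lower numbers stand for stronger inhibition and higher numbers for weaker inhibition), compound 1 `CCN(CC)S(=O)(=O)c1ccc(S(=O)(=O)N2CCC[C@@H](C(=O)NC3CN(C(=O)C4CC4)C3)C2)cc1` gives 3100 nM; compound 2 `CCOC(=O)[C@@H]1C[C@H](O)CN(S(=O)(=O)c2ccc(S(=O)(=O)N(CC)CC)cc2)C1` gives 300 nM; compound 3 `CCOC(=O)[C@@H]1CCCN(S(=O)(=O)c2ccc(S(=O)(=O)N3CCCCC3)cc2)C1` gives 1000 nM. Compound 1 stands at the highest of the three numbers: compound 3 is the nearest, with a lower number beyond the scatter, and compound 2 is the furthest, with a lower number also beyond the scatter. Compound 1 is therefore the weakest of the three on this assay.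

Compound 4 `CCN(CC)S(=O)(=O)c1ccc(S(=O)(=O)N2CCC[C@@H](C(=O)N[C@H]3CCN(C(=O)OC(C)(C)C)C3)C2)cc1` has not been measured. It differs from compound 1 in one place: 1-(tert-butoxycarbonyl)pyrrolidin-3-yl in place of 1-(cyclopropylcarbonyl)azetidin-3-yl on an amide-type nitrogen. For the measured compounds named here, no pair of measured compounds shows a change of this kind, and compounds 2 and 3 differ from compound 1 at other places, so the two values of each such pair show only the combined effect of several changes. The step from compound 1 to compound 4 is therefore expected to be none beyond the scatter, a 1.0-fold lower number from compound 1 to compound 4 (0.01 log units; within the scatter). Compound 4 is estimated at 3000 nM in this assay, with a range from 1000 nM to 9000 nM.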

Compound 4, half-maximal inhibitory concentration: 170 nM
The estimate for compound 4 lay 18-fold (1.25 log units) above the measured number; the measured number lies below the stated range.
By their numbers in this assay, from the lowest: compounds 4 and 2 (each within the scatter of the next); then compound 3; then compound 1.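

For the compounds shown here, the substituent on the amide-type nitrogen is clearly not a silent position in this assay: 1-(tert-butoxycarbonyl)pyrrolidin-3-yl in place of 1-(cyclopropylcarbonyl)azetidin-3-yl gives an 18-fold lower number from compound 1 to compound 4 (1.26 log units; beyond the scatter), and this is the first step that changes a single place. That one place swaps the ring and the acyl group together, a five-membered ring for a four-membered one and tert-butoxycarbonyl for cyclopropylcarbonyl, and the entering group also carries a defined stereocentre. No measurement available bears on why the step is this large.

The compounds shown do not separate the contribution of the ring from that of the acyl group, as neither changes alone. Also open, on these data alone, is how the free pyrrolidine amine, or an acetyl group on that nitrogen, or the opposite configuration at the stereocentre would read here.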